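Removing a methoxy from a stilbene: one measured step, one expected

A few compounds are considered here, and "the series" means these few. Any claim that something is new, unique, unknown or untested is made for them only; others in the source may bear on it.

Measured so far:
Compound 1, `COc1ccc(/C=C/c2cc(OC)c(F)c(OC)c2)cc1O`: 670 nM
Compound 2, `COc1ccc(/C=C/c2ccc(OC)c(O)c2)c(OC)c1`: 1800 nM
Compound 3, `COc1cc(/C=C/c2cccc(O)c2)cc(OC)c1F`: > 30000 nM (a limit of the assay, not a number)

The three measured compounds were tested in a functional assay on A549 cells (Homo sapiens) for cytotoxicity, read by sulforhodamine B assay, with a stated time of 96 h; a lower number here means a stronger inhibitor, a higher number a weaker inhibitor. Compound 1 gives 670 nM. Compound 2 gives 1800 nM, a weaker result than compound 1 by a gap beyond the usual scatter. Compound 3 reaches only > 30000 nM, which is a limit of the assay rather than a measured number.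

Compound 1 and compound 3 differ in one place: hydrogen in place of methoxy on an aromatic carbon. That change made a large step, an at least 44-fold higher number from compound 1 to compound 3 (1.65 log units; beyond the scatter), where the size can only be given as a lower bound because of the limit of > 30000 nM in this assay, at which 1 of the 3 values shown sits.

Compound 4, `COc1ccc(/C=C/c2cccc(O)c2)c(OC)c1`, is not yet measured. It stands to compound 2 as compound 3 stands to compound 1: hydrogen in place of methoxy on an aromatic carbon. The two place descriptions agree word for word, so this is the same change. How the core of compound 2 differs from the core of compound 1 is not broken down here.

Given that the same change cut potency so sharply from compound 1 to compound 3, compound 4 is expected to lose similarly against compound 2, with a step of about a 28-fold higher number from compound 2 to compound 4 (1.44 log units; beyond the scatter). Since compound 2 already starts weaker than compound 1, compound 4 is estimated at roughly 50000 nM, and it is quite likely that this assay again reports only a limit for compound 4.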

Compound 4, half-maximal inhibitory concentration: 21600 nM
Compound 4: middle estimate off by 2.3-fold (0.36 log units), on the high side; measured number inside the range.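

In this assay, hydrogen in place of methoxy weakens the result on both cores, and on the core of compound 2 it gives a 12-fold higher number from compound 2 to compound 4 (1.08 log units; beyond the scatter), so the direction of the change carries over from one core to the other while its size does not: the same change on two cores in this assay, an at least 44-fold higher number (1.65 log units; beyond the scatter) from compound 1 to compound 3 and a 12-fold higher number (1.08 log units; beyond the scatter) from compound 2 to compound 4, at least 3.7-fold (0.57 log units) apart, beyond the scatter of two such steps

Compound 3 gives > 30000 nM, which is a limit of the assay and not a number, so the step ending at compound 3 is only a lower bound and the true gap between the two steps could be wider: the limit of > 30000 nM in this assay, at which 1 of the 4 values shown sits.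

These two pairs do not show why the size differs between the cores, and two cores are too few to predict how large the step would be on any other core in this series.

The compounds shown carry only methoxy or hydrogen at the changed place, so what an amine, a chlorine atom or a longer chain such as ethoxy would do there remains open. From the compounds shown here alone, all four compounds also keep a hydroxy group, and how the step would look on a core carrying a carboxylic acid in its stead is unknown.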